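The compounds below may be only part of what the source reports. "The series", "measured", "known", "first", "only" and "open" are said of these compounds alone.

Three compounds share one core, and each was tested in an ADME assay on HEL cells (Homo sapiens) for cytotoxicity; on this read-out lower numbers stand for higher toxicity in this test and higher numbers for lower toxicity in this test. Compound 1 `COc1ccc(/C=N/NC(=O)COc2cccc3ccccc23)cc1O` gives 27.7 ug/mL in this assay. Compound 2 `O=C(COc1cccc2ccccc12)N/N=C/c1ccc([N+](=O)[O-])cc1` gives 14.2 ug/mL. Compound 3 `C/C(=N\NC(=O)COc1cccc2ccccc12)c1ccc(O)cc1` gives 11.1 ug/mL, the lowest of the three numbers; its gap to compound 2 lies within the usual scatter, so the two cannot be ranked against each other, while its gap to compound 1 lies beyond the scatter.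

Compound 4 `C/C(=N\NC(=O)COc1cccc2ccccc12)c1ccccc1Br` is not yet measured. It differs from compound 3 in one place: 2-bromophenyl in place of 4-hydroxyphenyl on a carbon with a double bond to nitrogen. Within the data shown here, no step between measured compounds shows what such a change does in this assay, so the direction is open. Among the measured compounds shown here, because compound 3 already gives 11.1 ug/mL and no measured pair points elsewhere, compound 4 is expected to land close to it, with a step of a 1.2-fold lower number from compound 3 to compound 4 (0.09 log units; within the scatter) that may not exceed the scatter. The estimate for compound 4 in this assay is 9 ug/mL, with a range from 4 ug/mL to 20 ug/mL.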

Compound 4, half-maximal cytotoxic concentration: 16.2 ug/mL
Beside the measured number, compound 4's estimate is 1.8-fold (0.26 log units) below it, and the stated range covers the measured number.
By their numbers in this assay, from the lowest: compounds 3, 2, 4 and 1 (each within the scatter of the next, the first and the last beyond it).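

In this assay, replacing 4-hydroxyphenyl with 2-bromophenyl on a carbon with a double bond to nitrogen gives a 1.5-fold higher number from compound 3 to compound 4 (0.16 log units; within the scatter), so this position accepts a large change of substituent without a readable shift in the number. The swap removes the hydroxyl group, with its hydrogen-bond donor and acceptor, and puts a bromine at a different ring position, yet the two compounds cannot be ranked against each other. No measurement shown bears on why the number stays within the scatter.

A 2-hydroxyphenyl or 4-bromophenyl group would be needed to separate the effect of the substituent from that of its ring position, and neither is among these compounds. Going by these compounds, it also remains open whether a 4-aminophenyl or 4-carboxyphenyl group here would move the number beyond the scatter.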